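Aryl swap on the ring amine of a thiophene ketone

A few compounds are considered here, and "the series" means these few. Any claim that something is new, unique, unknown or untested is made for them only; others in the source may bear on it.

Compounds measured so far:
compound 1, `Nc1scc(CN2CCN(c3cccc(Cl)c3Cl)CC2)c1C(=O)c1ccc(Cl)cc1`, -57%
compound 2, `Nc1scc(CN2CCN(c3ccccc3C(F)(F)F)CC2)c1C(=O)c1ccc(Cl)cc1`, -39%

In a functional assay on CHO cells with adenosine receptor A1 (Homo sapiens) as the target, read by cAMP accumulation and immunoassay, with a stated time of 6 min, tested at 1 uM (on this read-out lower numbers stand for a stronger effect and higher numbers for a weaker effect at the one concentration tested), compound 1 gives -57% and compound 2 gives -39%. Among the compounds with values here, compound 2 therefore stands highest of the two numbers, its only neighbour being compound 1, which sits lower. Within the data shown here, the one measured step, a number 18 percentage points higher from compound 1 to compound 2 (beyond the scatter), is modest and lies beyond the scatter; it arises from exchanging the aryl group on the amine nitrogen in the ring.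

Compound 3, `Nc1scc(CN2CCN(c3ccncc3)CC2)c1C(=O)c1ccc(Cl)cc1`, has not yet been measured. It differs from compound 2 as follows: pyridin-4-yl in place of 2-(trifluoromethyl)phenyl on an amine nitrogen in a ring

Among the measured compounds shown here, no measured step covers this exact exchange, so the step from compound 1 to compound 2 bears on it only as a sign that changing the aryl group at this place shifts the read-out by a modest amount. On that basis compound 3 is expected to move by a number 14 percentage points higher from compound 2 to compound 3 (beyond the scatter), towards a higher number, though the direction is uncertain. The estimate for compound 3 in this assay is -25%, with a range from -50% to 0%.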

Compound 3, a percentage reported as activity, at one concentration (the size of the read-out at that concentration, not a potency): -8.3%
Estimate against measurement, compound 3: 16.7 percentage points below; the measured number falls inside the stated range.
By their numbers in this assay, from the lowest: compound 1; then compound 2; then compound 3.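

In this assay the aryl group on the amine nitrogen in the ring turns out to control far more of the read-out than the modest earlier step suggested: pyridin-4-yl in place of 2-(trifluoromethyl)phenyl gives a number 30.7 percentage points higher from compound 2 to compound 3 (beyond the scatter) and pyridin-4-yl in place of 2,3-dichlorophenyl gives a number 48.7 percentage points higher from compound 1 to compound 3 (beyond the scatter) as the larger of the two new steps. Among these three compounds, the two with an aromatic ring of carbon only at this place give the lower numbers, while compound 3, with a ring nitrogen and a hydrogen-bond acceptor in the entering group, gives the highest, a pattern that rests on this single pyridine example. Nothing available explains why this exchange moves the read-out so far.

The compounds shown leave open whether the rise belongs to the ring nitrogen of pyridin-4-yl or to the loss of the chloro and trifluoromethyl groups, a question that an unsubstituted phenyl group at this place would help to separate. They also leave open how pyridin-3-yl or pyridin-2-yl would read on the same amine nitrogen.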